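The source may hold more compounds than are shown below. What is called first, only, known or untested is meant among the compounds shown, and "the series" means these compounds.

Compound 1 `COc1ccc(Br)cc1-c1cc(CN2CCN(C(=O)OC(C)(C)C)CC2)on1` carries a bromo group. In a functional assay on BV-2 cells (Mus musculus) for inhibition, read by Griess assay, with a stated time of 24 h (a higher number here means a weaker inhibitor, a lower number a stronger inhibitor), compound 1 gives > 200000 nM, which is a limit of the assay rather than a number. Compound 2 `C=CCc1ccc(OC)c(-c2cc(CN3CCN(C(=O)OC(C)(C)C)CC3)on2)c1` differs from it by one change (allyl in place of bromo on an aromatic carbon), and in this assay compound 2 gives 76900 nM. That step is an at least 2.6-fold lower number from compound 1 to compound 2 (0.41 log units; beyond the scatter). Compound 3 `CCOC(=O)COCc1cc(-c2cc(Br)ccc2OC)no1` rests on a different core; the difference between the two cores is not broken down here. In this assay compound 3 gives > 200000 nM, again a limit and not a number. Compound 4 `C=CCc1ccc(OC)c(-c2cc(COCC(=O)OCC)on2)c1` arises from compound 3 by the same change (allyl in place of bromo on an aromatic carbon). Because compound 3 also sits at the limit of > 200000 nM in this assay, at which 2 of the 3 values shown sit, the step of an at least 2.0-fold lower number from compound 3 to compound 4 (0.30 log units; that floor lies within the scatter) is expected, beside the earlier one. Compound 4 is thus estimated at 100000 nM, with a range from 40000 nM to 200000 nM, and a fair chance that only a limit is reported.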

Compound 4, half-maximal inhibitory concentration: 25900 nM
Estimate against measurement, compound 4: 3.9-fold (0.59 log units) above; the whole stated range lies above it.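

The switch from bromo to allyl gives an at least 7.7-fold lower number from compound 3 to compound 4 (0.88 log units; beyond the scatter), so in this assay the change points the same way on both cores shown. On these data alone, whether its size also carries over from one core to the other stays open: the same change on two cores in this assay, an at least 2.6-fold lower number (0.41 log units; beyond the scatter) from compound 1 to compound 2 and an at least 7.7-fold lower number (0.88 log units; beyond the scatter) from compound 3 to compound 4; the limit leaves it open whether they differ. Each step starts from a value that is only a limit, so each gives a floor and not a true size: the limit of > 200000 nM in this assay, at which 2 of the 4 values shown sit.

The compounds shown leave open whether allyl itself matters or whether another group in place of bromo, such as a propyl chain or an amine, would do the same. They also leave open whether the change holds on a core carrying a carboxylic acid in place of the ester.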